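Trimming Isopropyl to Ethyl on a Cytotoxic Core

This account rests on a few compounds, and the source may have more. Where it says the series, first, only, none or still open, it means among the compounds named here.

Of the compounds shown here, three have been tested in a functional assay on FaDu cells (Homo sapiens) for cytotoxicity, read by MTT assay, with a stated time of 72 h; on this read-out lower numbers stand for higher toxicity in this test and higher numbers for lower toxicity in this test. Compound 1 `COc1nc(NC(=O)C(=O)c2cn(C(C)C)c3ccccc23)ns1` reaches only the limit of > 10000 nM in this assay. Compound 3 `COc1ccc(NC(=O)C(=O)c2cn(C(C)C)c3ccccc23)nn1` gives 2270 nM in this assay. Compound 2 `COc1ccc(NC(=O)C(=O)c2cc(C(C)C)n3ccccc23)cn1` gives 160 nM in this assay, the lowest of the two numbers recorded, with compound 3 as the nearest value. Among the compounds with values here, the single measured step, an at least 4.4-fold lower number from compound 1 to compound 3 (0.64 log units; beyond the scatter), swaps the group on the amide-type nitrogen and says nothing about the other end of the molecule.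

Compound 4 `CCc1cc(C(=O)C(=O)Nc2ccc(OC)nc2)c2ccccn12` differs from compound 2 in one place: hydrogen in place of methyl on a saturated chain carbon bound to an aromatic carbon and a saturated chain carbon. Within the data shown here, no measured step touches this saturated chain carbon, so the size of the effect cannot be read from the compounds in hand. The isopropyl to ethyl change on the shared core is small, and a step no larger than the scatter is expected: compound 4 is estimated to give 220 nM in this assay, between 80 nM and 700 nM. This estimate means a step of a 1.4-fold higher number from compound 2 to compound 4 (0.14 log units; within the scatter), expected to stay within the usual scatter.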

Compound 4, concentration lethal to 50% of the cells: 110 nM
For compound 4 the middle estimate is 2.0-fold (0.30 log units) above the measured one, within the range that was stated.
By their numbers in this assay, from the lowest: compounds 4 and 2 (each within the scatter of the next); then compound 3. At a limit, above all of these: compound 1.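

In this assay, within the data shown here, the change from isopropyl to ethyl on the shared core gives a 1.5-fold lower number from compound 2 to compound 4 (0.16 log units; within the scatter) and is the first measured step at this saturated chain carbon. The earlier compounds shown here could not show what losing this methyl does, and this pair shows that the number stays within the scatter when hydrogen takes its place. The finding rests on this single pair and reaches no further than this change on this core.

The compounds shown leave open how the same position responds to larger changes, such as a longer chain, a cyclopropyl ring or an amine on the chain. Nothing in the data shown bears on why the number holds when this methyl leaves.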